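The source may report more compounds than this note shows. Statements on the series, on what has been measured and on what is new or still open speak of the compounds shown alone.

Two compounds have numbers in an assay for inhibition of Fatty-acid amide hydrolase 1 (Rattus norvegicus), using a Dixon plot; a higher number here means a weaker inhibitor, a lower number a stronger inhibitor. Compound 1 `N#C/C=C/c1ccc(-c2cnc(C(=O)CCCCCCc3ccccc3)o2)nc1` gives 2.1 nM in this assay. Compound 2 `COC(=O)CCCCc1cnc(C(=O)CCCCCCc2ccccc2)o1` gives 1.8 nM in this assay, the lowest of the two numbers, though its nearest neighbour is compound 1 and the gap between them lies within the scatter, so neither can be called the stronger inhibitor.

Compound 3 `O=C(CCCCCCc1ccccc1)c1ncc(CCCCCO)o1` has not yet been measured in this assay. It differs from compound 2 in one place: hydroxymethyl in place of methoxycarbonyl on a saturated chain carbon, four bonds along the chain from an aromatic carbon. Among the compounds with values here, no step between measured compounds speaks to this change, and the two measured compounds differ elsewhere. The step from compound 2 to compound 3 is therefore expected to be modest, most likely toward a somewhat higher number, and it may not exceed the scatter; the expected step is a 2.2-fold higher number from compound 2 to compound 3 (0.35 log units; beyond the scatter). On that basis compound 3 is estimated to give 4 nM in this assay, within a range from 1.2 nM to 15 nM.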

Compound 3, inhibition constant: 10.1 nM
Beside the measured number, compound 3's estimate is 2.5-fold (0.40 log units) below it; the range from low to high includes it.
By their numbers in this assay, from the lowest: compounds 2 and 1 (each within the scatter of the next); then compound 3.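

At this position on the saturated chain, the exchange of methoxycarbonyl for hydroxymethyl is not silent in this assay: it gives a 5.6-fold higher number from compound 2 to compound 3 (0.75 log units; beyond the scatter). Within the data shown here, this is the first sign that the group carried on this chain changes the number, something the earlier compounds could not show, as they differ elsewhere and lie within the scatter of each other. No measurement available here accounts for the step.

The compounds shown leave open whether a carboxylic acid or an amine in the same place would give a number nearer that of compound 2 or that of compound 3. They also leave open whether a longer chain ending in hydroxymethyl would widen or narrow the gap.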